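Fluoro for Nitro on the Urea Aryl Ring

This account rests on a few compounds, and the source may have more. Where it says the series, first, only, none or still open, it means among the compounds named here.

Of the compounds shown here, three sharing one core have been measured in an assay for binding affinity to Apoptosis regulator Bcl-2 (Homo sapiens), read by fluorescence polarization, with stated times of 30 min and 20 min, tested at 100 uM; a higher number here means more inhibition at the concentration tested (going by the name of the read-out), a lower number less inhibition. Compound 1 `COc1ccc(Oc2ccccc2-c2ccsc2S(=O)(=O)N2CCN(C(=O)Nc3cccc([N+](=O)[O-])c3)CC2)cc1OC` gives 18%, and compound 2 `COc1ccc(Oc2ccccc2-c2ccsc2S(=O)(=O)N2CCN(C(=O)Nc3ccc([N+](=O)[O-])cc3)CC2)cc1OC` gives 17%; the step of a number 1 percentage points lower from compound 1 to compound 2 (within the scatter) lies within the scatter. Compound 3 `O=C(Nc1ccc([N+](=O)[O-])cc1)N1CCN(S(=O)(=O)c2sccc2-c2ccccc2Oc2ccc(O)c(O)c2)CC1` gives 33%, and the step of a number 16 percentage points higher from compound 2 to compound 3 (beyond the scatter) is the only one of the two that stands beyond the scatter. Compound 2 thus holds the lowest of the three numbers, with compound 1 nearest and compound 3 furthest.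

Compound 4 `COc1ccc(Oc2ccccc2-c2ccsc2S(=O)(=O)N2CCN(C(=O)Nc3ccc(F)cc3)CC2)cc1OC` is not yet measured. Compared with compound 2 it differs as follows: fluoro in place of nitro on an aromatic carbon. Among the compounds with values here, of the measured steps, only the one from compound 1 to compound 2 touches the same aromatic ring, and that step was within the scatter; the step from compound 2 to compound 3 sits on a different part of the molecule and does not bear on this change. Within the data shown here, no measured step shows what replacing the nitro with fluoro does here. Compound 4 is therefore expected to land near compound 2, with a step of a number 2 percentage points lower from compound 2 to compound 4 (within the scatter) that stays within the scatter. The estimate for compound 4 in this assay is 15%, in a range from 4% to 30%.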

Compound 4, a percentage reported as inhibition, at one concentration (the size of the read-out at that concentration, not a potency): 15%
Compound 4: the middle estimate sits on the measured number at the digits printed, and the stated range covers the measured number.
By their numbers in this assay, from the lowest: compounds 4, 2 and 1 (each within the scatter of the next); then compound 3.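

Compounds 1 and 2 both carry a nitro, so they could not show whether that group itself matters at this position; compound 4 tests this directly, and in this assay the exchange of nitro for fluoro, on an aromatic carbon para to a large group, gives a number 2 percentage points lower from compound 2 to compound 4 (within the scatter) and stays within the scatter. The comparison with the other nitro isomer points the same way, with 4-fluorophenyl in place of 3-nitrophenyl giving a number 3 percentage points lower from compound 1 to compound 4 (within the scatter) and also staying within the scatter, so the three aryl groups on this nitrogen cannot be told apart in this read-out. With the 3,4-dimethoxyphenyl group in place, the nitro and its two hydrogen-bond acceptors can therefore be replaced by a single fluorine with no change beyond the scatter, and nothing at hand offers an explanation for this.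

The compounds shown leave open whether an amine or a carboxylic acid at this position would move the number beyond the scatter. They also leave open whether fluoro would behave the same way alongside the 3,4-dihydroxyphenyl group of compound 3, which gives 33% with a nitro on this ring.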